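The compounds below may be only part of what the source reports. "The series", "measured", "known", "first", "only" and "open" are said of these compounds alone.

On these data alone, compound 3 (`COc1cc2ncnc(-n3nc(-c4ccccn4)nc3N)c2cc1OCCCNC(=O)OCC(C)(C)C`) has no number in an ADME assay on BJ cells (Homo sapiens) for cytotoxicity, with a stated time of 72 h; a lower number here means that less compound is needed, a higher number that more compound is needed for the effect: its result reads "not determined" (no result reported), so its standing there remains open. Compound 1 (`COc1cc2ncnc(-n3nc(-c4ccccn4)nc3N)c2cc1[N+](=O)[O-]`) gives > 13000 nM, a limit of the assay. Compound 2 (`COCCOc1cc2c(-n3nc(-c4ccccn4)nc3N)ncnc2cc1OC`) gives > 13000 nM, also a limit. The change to compound 4 (`COc1cc2ncnc(-n3nc(-c4ccccn4)nc3N)c2cc1OCCCNC(=O)C(F)(F)F`) is trifluoromethyl in place of neopentyloxy on a carbonyl carbon. Within the data shown here, the only measured step, a step that the two limits leave unreadable from compound 1 to compound 2, concerns an aromatic carbon and has no readable size, so it gives no measure for this change. The remaining guide is the limit of > 13000 nM in this assay, at which 2 of the 3 values shown sit. Among the measured compounds shown here, no step of definite size or direction can be expected in this assay, and a further limit is the likeliest result. For compound 4 the expected value is 13000 nM, with an estimated range of 6000 nM to 30000 nM.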

Compound 4, half-maximal effective concentration: > 7000 nM
Compound 4: a limit, no number; the forecaster's own chance of this, stated with the estimate: 70%; the middle value lies beyond the limit too.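

In this assay compound 4 gives > 7000 nM, a limit and not a number. Among these compounds, compound 1, compound 2 and compound 4 all rest on limits, and no step among them can be read. Where compound 3 stands, and what number lies behind each limit, remains open.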